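The source may hold more compounds than are shown below. What is called first, only, known or untested is meant among the compounds shown, and "the series" means these compounds.

Measured compounds:
compound 1, `CCCCCCCCCCc1ccc(-c2ccnn2CCCN)cc1`, 45%
compound 2, `CCCCCCCCc1ccc(CCc2noc(CCCN)n2)cc1`, 40%
compound 3, `CCCCCCCCCOc1ccc(-c2noc(CCCN)n2)cc1`, 49%

In an assay on HeLa cells for inhibition of sphingosine-1-phosphate transporter SPNS2 (Mus musculus), read by LC-MS, tested at 2 uM (a lower number here means less inhibition, a higher number more inhibition at the concentration tested (going by the name of the read-out)), compound 3 gives 49%, the highest of the three numbers, though its nearest neighbour, compound 1 with 45%, lies within the scatter, as does compound 2 with 40%. On these numbers compound 3 cannot be said to give a higher number than the other two; the three values sit together.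

Compound 4, `CCCCCCCCCOc1ccc(-c2noc(CCCN)n2)cc1C(F)(F)F`, has not yet been measured in this assay. It differs from compound 3 in one place: trifluoromethyl in place of hydrogen on an aromatic carbon. Among the measured compounds shown here, no step between two measured compounds exists for a change of this kind, so there is no measured guide for its size.

The account expects that in this assay compound 4 shows a step of a number 4 percentage points lower from compound 3 to compound 4 (within the scatter) from compound 3, a small step that is not expected to go beyond the scatter in either direction. For compound 4 the estimate in this assay is 45%, with a range from 25% to 65%.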

Compound 4, a percentage reported as inhibition, at one concentration (the size of the read-out at that concentration, not a potency): 24%
For compound 4 the middle estimate is 21 percentage points above the measured one; measured number outside the range, below it.
By their numbers in this assay, from the lowest: compound 4; then compounds 2, 1 and 3 (each within the scatter of the next).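

In this assay, trifluoromethyl in place of hydrogen on an aromatic carbon, ortho to a large group and meta to a group of 9 heavy atoms, gives a number 25 percentage points lower from compound 3 to compound 4 (beyond the scatter), the only step among these compounds that is read as going beyond the scatter. Among the compounds shown here, it shows that this carbon of compound 3 is not indifferent to substitution, something the earlier compounds, whose values sit together, could not show. Nothing measured here accounts for the loss.

As far as these compounds go, whether a fluorine, a methyl or a methoxy group on the same carbon would keep the read-out of compound 3 stays open. So does whether trifluoromethyl would lower the read-out in the same way on the core of compound 1 or of compound 2.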